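This account rests on a few compounds, and the source may have more. Where it says the series, first, only, none or still open, it means among the compounds named here.

Compound 3 `C[C@@H](O[C@H]1CN2C(=O)C=C(c3cc[nH]c(=O)c3)CC2[C@@H]1c1ccc(F)cc1)c1cc(C(F)(F)F)cc(C(F)(F)F)c1` gives 0.27 nM in an assay on CHO cells for displacement of a labelled ligand from Substance-P receptor (Homo sapiens); on this read-out higher numbers stand for weaker inhibition and lower numbers for stronger inhibition. Of the three compounds measured, compound 3 sits second highest: compound 2 `C[C@@H](O[C@H]1CN2C(=O)C=C(c3ccncc3)CC2[C@@H]1c1ccc(F)cc1)c1cc(C(F)(F)F)cc(C(F)(F)F)c1` gives 0.14 nM, a gap covered by a 1.9-fold higher number from compound 2 to compound 3 (0.29 log units; within the scatter), while compound 1 `C[C@@H](O[C@H]1CN2C(=O)C=C(c3ccc(F)cc3)CC2[C@@H]1c1ccc(F)cc1)c1cc(C(F)(F)F)cc(C(F)(F)F)c1` gives 2 nM, reached by a 7.4-fold lower number from compound 1 to compound 3 (0.87 log units; beyond the scatter). Compound 4 `C[C@@H](O[C@H]1CN2C(=O)C=C(c3cnn(Cc4ccccc4)c3)CC2[C@@H]1c1ccc(F)cc1)c1cc(C(F)(F)F)cc(C(F)(F)F)c1` carries a group of 12 heavy atoms (10 carbon, 2 nitrogen; one five-membered aromatic ring with 2 hetero atoms, one six-membered aromatic ring of carbon only) in place of a group of 7 heavy atoms (5 carbon, 1 nitrogen, 1 oxygen; one six-membered aromatic ring with 1 hetero atom), on a double-bonded ring carbon. Among the compounds with values here, the steps that bear on this spot are a 14-fold lower number from compound 1 to compound 2 (1.15 log units; beyond the scatter) and a 7.4-fold lower number from compound 1 to compound 3 (0.87 log units; beyond the scatter), both lower numbers when a six-membered ring with one hetero atom replaced the carbon-only ring; no measured step covers a five-membered ring carrying a benzyl group. The change is therefore expected to give a somewhat higher number in this assay, as a 3.7-fold higher number from compound 3 to compound 4 (0.57 log units; beyond the scatter). Compound 4 is estimated at 1 nM, between 0.2 nM and 6 nM.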

Compound 4, half-maximal inhibitory concentration: 1.9 nM
The estimate for compound 4 lay 1.9-fold (0.28 log units) below the measured number; measured number inside the range.
By their numbers in this assay, from the lowest: compounds 2 and 3 (each within the scatter of the next); then compounds 4 and 1 (each within the scatter of the next).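

At this double-bonded ring carbon, 1-benzyl-1H-pyrazol-4-yl does not share the lower numbers of the two six-membered rings with one hetero atom (a 7.0-fold higher number from compound 3 to compound 4 (0.85 log units; beyond the scatter); a 14-fold higher number from compound 2 to compound 4 (1.13 log units; beyond the scatter)), and it stands level with 4-fluorophenyl (a 1.1-fold lower number from compound 1 to compound 4 (0.02 log units; within the scatter)). So in this assay hetero atoms in the ring are not enough on their own to give a lower number, as compound 4 shows against compounds 2 and 3. No evidence here explains these steps.

The compounds shown leave open whether the step belongs to the benzyl group or to the five-membered ring. A 1-methyl-1H-pyrazol-4-yl group in the same place would help separate the two.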